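The source may report more compounds than this note shows. Statements on the series, on what has been measured and on what is new or still open speak of the compounds shown alone.

For the measured compounds named here, in an ADME assay on J774.A1 cells (Mus musculus) for cytotoxicity, read by MTT assay, with a stated time of 72 h (a lower number here means that less compound is tolerated, a higher number that more compound is tolerated), three related compounds have numbers so far. Compound 1 `Clc1cccc(COC(CCn2ccnc2)c2cccs2)c1` gives 46000 nM, compound 2 `Clc1cccc(COC(CCn2cncn2)c2ccco2)c1` gives 18600 nM, and compound 3 `Clc1ccc(Cl)c(COC(CCn2ccnc2)c2ccco2)c1` gives 37600 nM. Compound 3 thus lies within the usual scatter of compound 1, while compound 2 stands lower than compound 3, beyond the scatter.

Compound 4 `Clc1cccc(COC(CCn2ccnc2)c2ccco2)c1` differs from compound 3 in one place: hydrogen in place of chloro on an aromatic carbon. In words, it has hydrogen in place of chloro on an aromatic carbon.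

Going by the values given here, no two measured compounds differ in only one place, so nothing yet shows the effect of this change directly. Among the compounds with values here, the only guide is the modest spread of the measured numbers, which runs from compound 2 at 18600 nM to compound 1 at 46000 nM. On that basis, no shift beyond the scatter is expected. The estimated step of a 1.1-fold higher number from compound 3 to compound 4 (0.04 log units; within the scatter) is slightly upward, but it stays within the scatter. For compound 4, the expected value is 41000 nM, with an estimated range of 20000 nM to 80000 nM.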

Compound 4, half-maximal cytotoxic concentration: 60200 nM
Estimate against measurement, compound 4: 1.5-fold (0.17 log units) below; low and high end bracket the measured number.
By their numbers in this assay, from the lowest: compound 2; then compounds 3, 1 and 4 (each within the scatter of the next).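

In this assay, swapping chloro for hydrogen on this aromatic carbon, ortho to a large group and para to a chloro group, gives a 1.6-fold higher number from compound 3 to compound 4 (0.20 log units; within the scatter), so this single change has no clear effect on the number here. The other two single changes behave differently: 1H-imidazol-1-yl in place of 1H-1,2,4-triazol-1-yl gives a 3.2-fold higher number from compound 2 to compound 4 (0.51 log units; beyond the scatter), a modest step beyond the scatter, whereas furan-2-yl in place of thiophen-2-yl gives a 1.3-fold higher number from compound 1 to compound 4 (0.12 log units; within the scatter), which stays within it. Nothing measured here explains any of these steps.

Going by these compounds, each change is seen only once, so it remains open whether the same steps would appear with other groups elsewhere on the shared core. On these data alone, how a fluoro, methoxy or amine group at this aromatic carbon would compare also remains open.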